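The source may report more compounds than this note shows. Statements on the series, on what has been measured and on what is new or still open speak of the compounds shown alone.

The study concerns a shared core of the kind seen in compound 2, `CC1(C)[C@@H]2CC[C@@]1(CS(=O)(=O)N1CCN(c3ccccn3)CC1)C(=O)C2`, in which a sulfonyl-linked saturated ring carries an aromatic group on its amine nitrogen. In a functional assay on CHO-K1 cells for antagonist activity at C-X-C chemokine receptor type 3 (Homo sapiens), read by FLIPR and calcium flux (on this read-out lower numbers stand for stronger inhibition and higher numbers for weaker inhibition), compound 2 gives > 31600 nM, which is a limit of the assay and not a number. Compound 1, `CC1(C)[C@@H]2CC[C@@]1(CS(=O)(=O)N1C[C@@H]3C[C@H]1CN3c1ccc(C(F)(F)F)cn1)C(=O)C2`, gives > 31600 nM in this assay, again a limit. Both thus stand at the limit of > 31600 nM in this assay, at which 2 of the 3 values shown sit. Among the compounds with values here, compound 3, `CC1(C)[C@@H]2CC[C@@]1(CS(=O)(=O)N1CCN(c3ncc(C(F)(F)F)cc3[N+](=O)[O-])CC1)C(=O)C2`, is the one compound with a measured number, giving 3160 nM in this assay.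

Compound 4, `CC1(C)[C@@H]2CC[C@@]1(CS(=O)(=O)N1CCN(c3ncc(Br)cn3)CC1)C(=O)C2`, has not yet been measured. It differs from compound 2 by 5-bromopyrimidin-2-yl in place of pyridin-2-yl on an amine nitrogen in a ring. Within the data shown here, no step between measured compounds exists here, so the expectation rests on compound 3 alone: an aromatic group bearing substituents gave a number, where the bare pyridin-2-yl of compound 2 gave only a limit. For compound 4 a move from the limit toward measurable inhibition is therefore expected, of size an at least 2.6-fold lower number from compound 2 to compound 4 (0.42 log units; beyond the scatter), though a result at the limit remains quite possible. The expected value for compound 4 in this assay is 12000 nM, within a range from 3000 nM to 40000 nM.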

Compound 4, half-maximal inhibitory concentration: 631 nM
Compound 4: the middle estimate sits 19-fold (1.28 log units) above what was measured; the measured number lies below the stated range.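

Changing only the aromatic group on the ring amine nitrogen, with the rest of the shared core untouched, gives an at least 50-fold lower number from compound 2 to compound 4 (1.69 log units; beyond the scatter) in this assay. Within the data shown here, this is the first single-place change that can be read here, and it shows that this position alone can separate a compound stuck at the limit from one with a measured number. Compound 2 gives only a limit of the assay, so the step has a lower bound and no exact size: the limit of > 31600 nM in this assay, at which 2 of the 4 values shown sit.

The compounds shown leave open which part of the change carries the step, the bromine or the second ring nitrogen, since both enter together. On these data alone, a pyrimidine ring without the bromine, or a pyridine ring carrying it, would separate the two, and whether a chlorine or a methyl group could stand in place of the bromine is equally open.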